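A few compounds are considered here, and "the series" means these few. Any claim that something is new, unique, unknown or untested is made for them only; others in the source may bear on it.

Working notes on the series. In a functional assay on MCF7 cells (Homo sapiens) for antiproliferative activity (on this read-out higher numbers stand for weaker inhibition and lower numbers for stronger inhibition), compound 1 (`CC(C)=CCc1cc(C(=O)Nc2cc3ccc(OCCC4CCCCN4)c(C)c3oc2=O)ccc1O`) gives 710 nM, compound 2 (`CC(C)=CCc1cc(C(=O)Nc2cc3ccc(OCCCNCC(C)C)c(C)c3oc2=O)ccc1O`) gives 1320 nM and compound 3 (`CC(C)=CCc1cc(C(=O)Nc2cc3ccc(OCCCNCC(N)=O)c(C)c3oc2=O)ccc1O`) gives 1460 nM. Compound 3 is level with compound 2 and stands apart only from compound 1, on the side of the higher number. The next structure is compound 4 (`CC(C)=CCc1cc(C(=O)Nc2cc3ccc(OCCCNC4CCCCC4)c(C)c3oc2=O)ccc1O`), which differs from compound 3 as follows: cyclohexyl in place of carbamoylmethyl on an amine nitrogen. In short, cyclohexyl takes the place of carbamoylmethyl on an amine nitrogen.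

Within the data shown here, three measured steps bear on this. Among the measured compounds shown here, the closest precedent is carbamoyl in place of isopropyl, which gave a 1.1-fold higher number from compound 2 to compound 3 (0.04 log units; within the scatter). Changing from piperidin-2-yl to (isobutylamino)methyl gave a 1.9-fold higher number from compound 1 to compound 2 (0.27 log units; within the scatter). For the measured compounds named here, changing from piperidin-2-yl to ((carbamoylmethyl)amino)methyl gave a 2.1-fold higher number from compound 1 to compound 3 (0.31 log units; beyond the scatter), the only step beyond the scatter, and a modest one. Compound 4 carries a ring, as compound 1 does, but its ring stands on the amine nitrogen, so compound 1 is only a loose guide. In this assay a small shift towards a lower number is expected, with no step beyond the scatter. The estimated step is a 1.5-fold lower number from compound 3 to compound 4 (0.16 log units; within the scatter). For compound 4 the expected value is 1000 nM, with an estimated range of 520 nM to 1950 nM.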

Compound 4, half-maximal inhibitory concentration: 1070 nM
Estimate against measurement, compound 4: 1.1-fold (0.03 log units) below, and the stated range covers the measured number.
By their numbers in this assay, from the lowest: compounds 1, 4, 2 and 3 (each within the scatter of the next, the first and the last beyond it).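

In this assay, cyclohexyl on the amine nitrogen, a six-membered non-aromatic ring of carbon only with no hydrogen-bond donors or acceptors, replaces carbamoylmethyl with a 1.4-fold lower number from compound 3 to compound 4 (0.13 log units; within the scatter) and isobutyl with a 1.2-fold lower number from compound 2 to compound 4 (0.09 log units; within the scatter), so three quite different groups at this position now sit within the scatter of one another. Against compound 1, the change to (cyclohexylamino)methyl from piperidin-2-yl gives a 1.5-fold higher number from compound 1 to compound 4 (0.18 log units; within the scatter), which leaves a 2.1-fold higher number from compound 1 to compound 3 (0.31 log units; beyond the scatter) as the only step in the series beyond the scatter, and a ring on the amine nitrogen does not separate compound 4 from compound 1. No measurement at hand accounts for any of these steps.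

On these data alone, it remains open whether phenyl or benzyl on the amine nitrogen, or a carboxylic acid in place of the carbamoyl group, would give a step beyond the scatter. Also open, as far as these compounds go, is how a longer chain from the oxygen on the aromatic ring to the amine, or a second alkyl group on that nitrogen, would read in this assay.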